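Dropping the Trifluoromethyl from a Benzylsulfanyl Arm

This account rests on a few compounds, and the source may have more. Where it says the series, first, only, none or still open, it means among the compounds named here.

Compound 2 `Cc1cc(-c2ccccc2)n(/C(N)=N/S(=O)(=O)c2cc(C)c(Cl)cc2SCc2ccccc2C(F)(F)F)n1` gives 215000 nM in a functional assay on HeLa cells (Homo sapiens) for cytotoxicity, read by MTT assay, with a stated time of 72 h (a lower number here means a stronger inhibitor, a higher number a weaker inhibitor), the highest of the three numbers measured. Compound 1 `Cc1cc(S(=O)(=O)/N=C(\N)n2nccc2-c2ccccc2)c(SCc2ccccc2Cl)cc1Cl` gives 19000 nM and compound 3 `Cc1cc(S(=O)(=O)/N=C(\N)n2nccc2-c2ccccc2)c(SCc2cccc(Cl)c2)cc1Cl` gives 10000 nM; both lie beyond the scatter below compound 2. Compound 4 `Cc1cc(-c2ccccc2)n(/C(N)=N/S(=O)(=O)c2cc(C)c(Cl)cc2SCc2ccccc2)n1` differs from compound 2 in one place: hydrogen in place of trifluoromethyl on an aromatic carbon. Among the measured compounds shown here, no measured step matches this change. For the measured compounds named here, the only measured step, a 1.9-fold lower number from compound 1 to compound 3 (0.28 log units; within the scatter), moves a chlorine around the same benzyl ring and stays within the scatter, so it offers little guidance. Compound 4 is expected to move downward, as a 5.4-fold lower number from compound 2 to compound 4 (0.73 log units; beyond the scatter), because compound 1 gives 19000 nM and compound 3 gives 10000 nM, both far below compound 2. The estimate for compound 4 is 40000 nM, between 10000 nM and 160000 nM.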

Compound 4, half-maximal inhibitory concentration: 5000 nM
Compound 4: middle estimate off by 8.0-fold (0.90 log units), on the high side; the measured number lies below the stated range.
By their numbers in this assay, from the lowest: compounds 4, 3 and 1 (each within the scatter of the next, the first and the last beyond it); then compound 2.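

In this assay the loss of the trifluoromethyl brings a 43-fold lower number from compound 2 to compound 4 (1.63 log units; beyond the scatter) while the earlier step, a 1.9-fold lower number from compound 1 to compound 3 (0.28 log units; within the scatter), stayed within the scatter. This shows that the substituent on this aromatic carbon of the benzylsulfanyl arm, ortho to a large group, can change the number greatly, which moving a chlorine around the ring did not show. No measured evidence here explains the size of this step. Still open, from the compounds shown here alone, is how a methoxy group or a single fluorine at this place would compare with hydrogen and trifluoromethyl.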